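The source may report more compounds than this note shows. Statements on the series, on what has been measured and on what is new or still open speak of the compounds shown alone.

Measured so far:
compound 1, `Nc1cc(N)c2nc(-c3ccccc3)c(Oc3ccc(Cl)c(Cl)c3)nc2c1` — 8320 nM
compound 2, `CCOC(=O)[C@H](CCC(=O)O)NC(=O)c1ccc(Sc2nc3cc(N)cc(N)c3nc2-c2ccccc2)cc1` — 21400 nM

Both compounds share the same diamino core with a phenyl group, and differ in the group attached to the aromatic carbon next to the ring nitrogen. In a functional assay on NCI-H522 cells (Homo sapiens) for inhibition, read by sulforhodamine B assay, with a stated time of 48 h (a lower number here means a stronger inhibitor of growth, a higher number a weaker inhibitor of growth), compound 1 gives 8320 nM; compound 2 gives 21400 nM, a higher number than compound 1 and beyond the usual scatter. Compound 1 thus stands as the lower of the two numbers. Going by the values given here, no step between two compounds differing in a single place has been measured, so no calibrated size for any change is available.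

Compound 3, `Nc1cc(N)c2nc(-c3ccccc3)c(Sc3ccc(Cl)c(Cl)c3)nc2c1`, has not been measured in this assay. It differs from compound 1 in one place: (3,4-dichlorophenyl)sulfanyl in place of 3,4-dichlorophenoxy on an aromatic carbon The aryl part and its two chlorines stay; only the linking atom changes. Among the compounds with values here, with no measured step of this kind to lean on, the expected change is small, in either direction, and most likely not beyond the scatter. The estimate for compound 3 in this assay is 10000 nM, with a range of 4000 nM to 25000 nM. This estimated step, a 1.2-fold higher number from compound 1 to compound 3 (0.08 log units; within the scatter), is expected to stay close to the scatter.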

Compound 3, concentration for 50% growth inhibition: 7590 nM
Beside the measured number, compound 3's estimate is 1.3-fold (0.12 log units) above it; measured number inside the range.
By their numbers in this assay, from the lowest: compounds 3 and 1 (each within the scatter of the next); then compound 2.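

In this assay, the replacement of 3,4-dichlorophenoxy by (3,4-dichlorophenyl)sulfanyl on this aromatic carbon, next to the ring nitrogen and ortho to a phenyl group, gives a 1.1-fold lower number from compound 1 to compound 3 (0.04 log units; within the scatter), so the two compounds cannot be told apart in this read-out. With the aryl part and its two chlorines held fixed, the oxygen link and the sulfur link read alike here; compound 1 and compound 2 differ in the whole group at this place, and the effect of the linking atom alone could not be read from them. Nothing measured on these compounds bears on why the two links read alike.

Still open, as far as these compounds go, is whether this place accepts other links between the core and the 3,4-dichlorophenyl ring, such as an amine nitrogen, a methylene or a longer chain, or whether the match is limited to oxygen and sulfur. Also open, from the compounds shown here alone, is whether the same match between oxygen and sulfur holds with other aryl parts, for example a plain phenyl or a pyridine ring, since a single pair with one aryl group sets no general rule for this position.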